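The source may report more compounds than this note shows. Statements on the series, on what has been measured and on what is new or still open speak of the compounds shown alone.

Compound 1 `COc1ccc(N(CC(=O)NCCC[Te]c2ccccc2)C(=O)CNC(=O)OC(C)(C)C)cc1`: < 100000 nM
Compound 2 `COc1ccc(N(CC(=O)NCCC[Te]c2ccccc2)C(=O)CCSC2=C(C)C(=O)c3ccccc3C2=O)cc1`: 5130 nM
Compound 3 `CC1=C(SCCC(=O)OCC(=O)NCCC[Te]c2ccccc2)C(=O)c2ccccc2C1=O`: 34700 nM

All three compounds carry the same chain ending in a tellurium-bearing phenyl group and were tested in a functional assay on K562 cells (Homo sapiens) for inhibition, with a stated time of 48 h; a lower number here means a stronger inhibitor of growth, a higher number a weaker inhibitor of growth. Compound 2 gives 5130 nM and compound 3 gives 34700 nM. For compound 1 the result is only a limit, < 100000 nM, so no exact number is known for it (the limit of < 100000 nM in this assay, at which 1 of the 3 values shown sits). Compound 4 `COc1ccc(N(CC(=O)NCCC[Te]c2ccccc2)C(=O)c2ccccc2)cc1` is compound 1 with a single change: phenyl in place of ((tert-butoxycarbonyl)amino)methyl on a carbonyl carbon. Among the measured compounds shown here, no pair of measured compounds differs in only one place, so no measured step can guide this one directly. The expected step from compound 1 to compound 4 in this assay is a step that the limit leaves unreadable from compound 1 to compound 4. With compound 1 known only as a limit, this expectation is rough. Compound 4 is expected to give about 30000 nM in this assay, with a likely range from 5000 nM to 100000 nM.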

Compound 4, concentration for total growth inhibition: < 100000 nM
Compound 4 was reported as a limit; the forecaster's own chance of this, stated with the estimate: 35%; the middle value is on the limit's open side.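

Compound 1 and compound 4 are both reported only as limits, so no step can be read between them: the limit of < 100000 nM in this assay, at which 2 of the 4 values shown sit.

The compounds shown leave open whether phenyl in place of ((tert-butoxycarbonyl)amino)methyl changes growth inhibition at all, and if so, in which direction and by how much.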